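Aryl variation on the enol-diketone core: forecast for compound 4

A few compounds are considered here, and "the series" means these few. Any claim that something is new, unique, unknown or untested is made for them only; others in the source may bear on it.

The shared core of compound 2 `COC1=C(C)C(=O)/C(=C(O)/C=C/c2ccccc2OC)C(=O)C1(C)C` carries a 2-methoxyphenyl on the double-bonded chain. Going by the values given here, in a functional assay on PC-3 cells (Homo sapiens) for cytotoxicity (on this read-out higher numbers stand for an effect only at larger amounts of compound and lower numbers for an effect already at smaller amounts), compound 2 gives 15.6 ug/mL, the highest of the three numbers measured so far. Compound 1 `COC1=C(C)C(=O)/C(=C(O)/C=C/c2cccc(OC)c2)C(=O)C1(C)C` gives 14.3 ug/mL, and the step of a 1.1-fold higher number from compound 1 to compound 2 (0.04 log units; within the scatter) is within the scatter. Compound 3 `COC1=C(C)C(=O)/C(=C(O)/C=C/c2ccc(F)cc2)C(=O)C1(C)C` gives 7.2 ug/mL; the step of a 2.2-fold lower number from compound 2 to compound 3 (0.34 log units; beyond the scatter) is the only one beyond the scatter, and a 2.0-fold lower number from compound 1 to compound 3 (0.30 log units; within the scatter) falls within it.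

Compound 4 `COC1=C(C)C(=O)/C(=C(O)/C=C/c2cc(C)cc(C)c2)C(=O)C1(C)C` differs from compound 2 only at the aryl group: 3,5-dimethylphenyl in place of 2-methoxyphenyl on a double-bonded chain carbon bound to a double-bonded chain carbon. Among the compounds with values here, the steps that bear on this change are the three aryl swaps already measured. Two of them are within the scatter and one, from compound 2 to compound 3, is modest. The 3,5-dimethylphenyl of compound 4 takes away the single hydrogen-bond acceptor of the 2-methoxyphenyl, a change not yet covered by any measured pair, so the forecast leans on the small size of all aryl steps seen so far.

A slight lowering is expected, a 1.6-fold lower number from compound 2 to compound 4 (0.19 log units; within the scatter), on the side of the step from compound 2 to compound 3 rather than beyond it. Compound 4 is therefore estimated at 10 ug/mL, with a range from 5 ug/mL to 22 ug/mL.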

Compound 4, concentration for half-maximal effect: 8.8 ug/mL
Compound 4: the middle estimate sits 1.1-fold (0.06 log units) above what was measured, within the range that was stated.
By their numbers in this assay, from the lowest: compounds 3, 4, 1 and 2 (each within the scatter of the next, the first and the last beyond it).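

The swap of 2-methoxyphenyl for 3,5-dimethylphenyl at this place on the chain replaces an oxygen-bearing aryl group with an all-carbon one of the same heavy-atom count and removes the hydrogen-bond acceptor, yet in this assay the result is a 1.8-fold lower number from compound 2 to compound 4 (0.25 log units; within the scatter). The comparison with the other methoxy isomer reads the same way, with a 1.6-fold lower number from compound 1 to compound 4 (0.21 log units; within the scatter), so the oxygen of the methoxy group is not needed to keep the read-out in this range, at least for these aryl groups. Against the fluorinated compound the step is a 1.2-fold higher number from compound 3 to compound 4 (0.09 log units; within the scatter), so 3,5-dimethylphenyl and 4-fluorophenyl cannot be told apart here, and nothing measured on these compounds accounts for any of these steps.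

All four aryl groups shown are neutral phenyl rings, so it remains open whether an amine or a carboxylic acid on the ring would give a step clearly beyond the scatter. Also open, as far as these compounds go, is whether the phenyl ring itself is needed at this place, which a cyclohexyl group or a longer alkyl chain in its stead would test.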